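The compounds below may be only part of what the source reports. "The series", "measured", "known", "first", "only" and "open" are said of these compounds alone.

Measured compounds and their values:

compound 1 `CC1(C)C[C@]23[C@@H](C(=O)O)CC[C@H]1[C@@H]2CC(=O)[C@@H]3CO`: 14500 nM
compound 2 `C=C1C(=O)C[C@H]2[C@@H]3CC[C@H](C(=O)O)[C@]12CC3(C)C`: 10600 nM
compound 3 `COC1=C(c2c[nH]c3ccccc23)C(=O)C(OC)=C(c2c[nH]c3ccccc23)C1=O`: 19900 nM

All three values come from a functional assay on NCI-H460 cells (Homo sapiens) for cytotoxicity, read by MTT assay, with a stated time of 48 h; on this read-out higher numbers stand for weaker inhibition and lower numbers for stronger inhibition. In this assay compound 3 gives the highest of the three numbers, yet its gaps to compound 1 and to compound 2 both fall within the scatter, so no ordering among the three can be read from these values. Within the data shown here, compound 1 and compound 2 share a core that differs from that of compound 3, and no step between any two measured compounds is defined.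

The next compound, compound 4 `C=CC(C)(C)c1[nH]c2ccccc2c1C1=C(OC)C(=O)C(c2c[nH]c3ccccc23)=C(OC)C1=O`, keeps the core of compound 3 and carries one change: 1,1-dimethylprop-2-en-1-yl in place of hydrogen on an aromatic carbon. The group enters on an aromatic carbon of a five-membered aromatic ring with one nitrogen, next to the ring nitrogen. Among the measured compounds shown here, no measured pair informs this kind of change, so the size of the step is uncertain. Compound 4 is expected to give 15000 nM, within a range of 5000 nM to 45000 nM. This estimate means a step of a 1.3-fold lower number from compound 3 to compound 4 (0.12 log units; within the scatter) that is expected to stay within the scatter, with no clear direction.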

Compound 4, half-maximal inhibitory concentration: 24200 nM
Compound 4: middle estimate off by 1.6-fold (0.21 log units), on the low side, and the stated range covers the measured number.
By their numbers in this assay, from the lowest: compounds 2, 1, 3 and 4 (each within the scatter of the next, the first and the last beyond it).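

In this assay the series now has its first pair differing in one place, and 1,1-dimethylprop-2-en-1-yl in place of hydrogen gives a 1.2-fold higher number from compound 3 to compound 4 (0.08 log units; within the scatter). This aromatic carbon of the five-membered aromatic ring, next to the ring nitrogen, therefore carries the group without a step beyond the scatter, so the read-out gives no direction for this change. No measured information is available to account for this result.

This position is informed by a single substitution on a single core, so the step says nothing yet about how other groups behave there. As far as these compounds go, whether an amine or a methyl on the same carbon would also stay within the scatter of compound 3 remains open.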